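The source may hold more compounds than are shown below. What is called first, only, known or untested is meant among the compounds shown, and "the series" means these compounds.

In a functional assay on HEK293 cells for positive allosteric modulation of metabotropic glutamate receptor 5 (Homo sapiens), read by calcium flux (a higher number here means a larger maximal response, a lower number a smaller maximal response), compound 1 `COc1ccc(N2CCn3nc(COc4ccccc4)cc3C2=O)cc1` gives 58%. Compound 2 `O=C1c2cc(COc3ccccc3F)nn2CCN1c1ccc(F)cc1` gives 66% in this assay, and these two numbers lie within the usual scatter of each other, so nothing separates compound 2 from compound 1 on this read-out. Compound 3 `O=C1c2cc(COc3ccncc3)nn2CCN1c1ccc(F)cc1` has not yet been measured. It differs from compound 2 in one place: pyridin-4-yl in place of 2-fluorophenyl on an oxygen on a saturated carbon. Going by the values given here, no measured pair in this set carries the same change, so there is no step to lean on. With only the two close-lying values of compound 1 and compound 2 to go by, the step is expected to be a number 6 percentage points lower from compound 2 to compound 3 (within the scatter), which would stay inside the scatter. For compound 3 the largest response in this assay is therefore estimated at 60%, with a range from 40% to 80%.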

Compound 3, largest response reached (Emax), in percent of the reference or control that the assay uses: 69%
For compound 3 the middle estimate is 9 percentage points below the measured one, and the stated range covers the measured number.
By their numbers in this assay, from the lowest: compounds 1, 2 and 3 (each within the scatter of the next, the first and the last beyond it).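

Placing pyridin-4-yl in place of 2-fluorophenyl on an oxygen on a saturated carbon gives a number 3 percentage points higher from compound 2 to compound 3 (within the scatter) in this assay, the first step read at this position. The change removes the fluorine and the carbon-only ring and brings in an aromatic ring with one hetero atom and one hydrogen-bond acceptor, yet compound 3 at 69% cannot be told apart from compound 2 on this read-out. This position therefore accepts this one change without a step beyond the scatter, though that holds only for this pair.

On these data alone, whether pyridin-3-yl, a saturated amine such as piperidin-4-yl, or a group carrying a carboxylic acid would read the same in this place remains open. So does whether the same change would give a similar step on a compound with a different group elsewhere on the core. Nothing available here accounts for the result.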